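Ethoxymethyl to (benzyloxy)methyl: cytotoxicity notes on the series

The source may hold more compounds than are shown below. What is called first, only, known or untested is meant among the compounds shown, and "the series" means these compounds.

Measured in an ADME assay on MT4 cells (Homo sapiens) for cytotoxicity, read by XTT assay, with a stated time of 3 days; on this read-out lower numbers stand for higher toxicity in this test and higher numbers for lower toxicity in this test:
compound 1 `CCOCn1c(Cc2cc(C)cc(C)c2)c(I)c(=O)[nH]c1=O` gives 142000 nM
compound 2 `Cc1cc(C)cc(Cc2c(I)c(=O)[nH]c(=O)n2COCc2ccccc2)c1` gives 98300 nM
compound 3 `CCOCn1c(Cc2ccccc2)c(N(C)C)c(=O)[nH]c1=O` gives 166000 nM

Compound 4 `CN(C)c1c(Cc2ccccc2)n(COCc2ccccc2)c(=O)[nH]c1=O` has not been measured. It differs from compound 3 by phenyl in place of methyl on a saturated chain carbon bound to an oxygen on a saturated carbon. The same change separates compound 1 from compound 2: phenyl in place of methyl on a saturated chain carbon bound to an oxygen on a saturated carbon. The two place descriptions agree word for word, so this is the same change made on two cores. How the core of compound 3 differs from the core of compound 1 is not broken down here; the two cores differ in more than one place.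

Within the data shown here, the one measured instance of the change, a 1.4-fold lower number from compound 1 to compound 2 (0.16 log units; within the scatter), stays within the scatter of this assay. Among the measured compounds shown here, with only that precedent, the step from compound 3 to compound 4 in this assay is expected to be of similar size, a 1.3-fold lower number from compound 3 to compound 4 (0.11 log units; within the scatter), resting on compound 1 giving 142000 nM and compound 2 giving 98300 nM. Compound 4 is therefore estimated at 130000 nM, with a range of 70000 nM to 240000 nM.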

Compound 4, half-maximal cytotoxic concentration: 91800 nM
Compound 4: middle estimate off by 1.4-fold (0.15 log units), on the high side, within the range that was stated.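

In this assay, the second instance of ethoxymethyl to (benzyloxy)methyl reads a 1.8-fold lower number from compound 3 to compound 4 (0.26 log units; within the scatter). Set beside the first instance, the change carries over from one core to the other with no difference that can be told from the scatter: the same change on two cores in this assay, a 1.4-fold lower number (0.16 log units; within the scatter) from compound 1 to compound 2 and a 1.8-fold lower number (0.26 log units; within the scatter) from compound 3 to compound 4, 1.3-fold (0.10 log units) apart, within the scatter of two such steps.
Among these compounds, this shows only that the step stays within the scatter on these two cores; it does not show that the change has a fixed size or that it would read alike on a further core, as each core supplies a single pair and neither step stands clear of the scatter.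

The cores of compound 1 and compound 3 differ in more than one place, so these compounds leave open which of those differences, if any, bears on the size of the step. Also open, on these data alone, is how an amine or a carboxylic acid on the phenyl that enters, or a longer chain in place of the benzyl, would read in this assay.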